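The compounds below may be only part of what the source reports. "The series", "measured", "known", "first", "only" and "open" are said of these compounds alone.

Measured so far:
Compound 1 `COc1ccc(C(=O)/C=C/c2ccc(F)cc2)c2c1C=CC(C)(C)O2` — in a functional assay on HepG2 cells (Homo sapiens) for antiproliferative activity, read by MTT assay, with a stated time of 24 h (a lower number here means a stronger inhibitor, a higher number a weaker inhibitor), compound 1 gives > 10000 nM, a limit of the assay rather than a number.
Compound 2 `COc1ccc(C(=O)/C=C/c2ccc(Br)cc2)c2c1C=CC(C)(C)O2` — in this assay compound 2 gives > 10000 nM, again a limit.
Compound 3 `CCN(CC)c1ccc(/C=C/C(=O)c2ccc(OC)c3c2OC(C)(C)C=C3)cc1` — in this assay compound 3 gives 590 nM.

Among the compounds with values here, compound 3 therefore holds the only real number among the three; the other two sit at a limit (the limit of > 10000 nM in this assay, at which 2 of the 3 values shown sit). Compound 4 `COc1ccc(C(=O)/C=C/c2ccccc2)c2c1C=CC(C)(C)O2` differs from compound 3 by one change: hydrogen in place of diethylamino on an aromatic carbon. Within the data shown here, two measured steps bear on this. Introducing the diethylamino group gave an at least 16-fold lower number from compound 1 to compound 3 (1.22 log units; beyond the scatter) and an at least 16-fold lower number from compound 2 to compound 3 (1.22 log units; beyond the scatter), both large. Removing it is expected to run the other way, so a large rise in this assay is expected, a 20-fold higher number from compound 3 to compound 4 (1.31 log units; beyond the scatter). Compound 4 is estimated at 12000 nM, within 3000 nM to 40000 nM, quite possibly reported only as a limit.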

Compound 4, half-maximal inhibitory concentration: > 10000 nM
Compound 4 gave a limit, no number (the forecaster's own chance of this, stated with the estimate: 65%); the middle value is on the limit's open side.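

Removing the diethylamino group altogether gives an at least 16-fold higher number from compound 3 to compound 4 (1.22 log units; beyond the scatter) in this assay. The low number of compound 3 therefore depends on the diethylamino group itself, and not merely on the absence of fluoro or bromo at this position. The steps from compound 1 and compound 2 to compound 4 cannot be read, so hydrogen, fluoro and bromo cannot be ranked, because all three compounds sit at a limit: the limit of > 10000 nM in this assay, at which 3 of the 4 values shown sit.

Going by these compounds, whether a smaller amine such as dimethylamino, or a ring amine such as morpholine, would keep a low number here stays open.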